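This account rests on a few compounds, and the source may have more. Where it says the series, first, only, none or still open, it means among the compounds named here.

Compounds measured so far:
compound 1, `CCCCCCCC/C=C/CCCCCCCC(=O)O[C@H]1[C@H](O)[C@H](n2ccc(N)nc2=O)O[C@@H]1CO` — 0.05 ug/mL
compound 2, `CCCCCCCC/C=C\CCCCCCCCCCCC(=O)O[C@H]1[C@H](O)[C@H](n2ccc(N)nc2=O)O[C@@H]1CO` — 0.16 ug/mL

Both compounds were tested in a functional assay on HeLa cells (Homo sapiens) for cytotoxicity, read by cell counting, with a stated time of 48 h; a higher number here means that more compound is needed for the effect, a lower number that less compound is needed. Compound 1 gives 0.05 ug/mL in this assay, while compound 2 gives 0.16 ug/mL. Compound 2 therefore stands highest of the two numbers, and its nearest neighbour, compound 1, sits at a lower number by a margin beyond the usual scatter.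

The next compound, compound 3, `CCCCCCCCCCC(=O)O[C@H]1[C@H](O)[C@H](n2ccc(N)nc2=O)O[C@@H]1CO`, has not yet been measured in this assay. Relative to compound 2 it differs in one place: hydrogen in place of undec-2-en-1-yl on a saturated chain carbon, ten or more bonds along the chain from a carbonyl carbon. The ester chain is thus cut back to a saturated chain, with no double bond left.

For the measured compounds named here, no step between measured compounds with the same kind of change exists, so the expectation rests on the two values alone. The chain of compound 2 is the longer of the two, and since compound 1 gives 0.05 ug/mL, a shorter chain is expected to move the number down rather than up, by a modest amount. The step from compound 2 to compound 3 is expected to be a 2.0-fold lower number from compound 2 to compound 3 (0.30 log units; within the scatter). Compound 3 is estimated at 0.08 ug/mL, within a range from 0.02 ug/mL to 0.3 ug/mL.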

Compound 3, concentration for half-maximal effect: 0.04 ug/mL
Compound 3: middle estimate off by 2.0-fold (0.30 log units), on the high side; measured number inside the range.
By their numbers in this assay, from the lowest: compounds 3 and 1 (each within the scatter of the next); then compound 2.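

In this assay, hydrogen in place of undec-2-en-1-yl on a saturated chain carbon, ten or more bonds along the chain from a carbonyl carbon, gives a 4.0-fold lower number from compound 2 to compound 3 (0.60 log units; beyond the scatter), a step beyond the scatter, so the outer part of the long unsaturated chain of compound 2 is not needed for the effect at this position, and the number improves without it. The second step, a group of 3 heavy atoms in place of a group of 10 heavy atoms on a saturated chain carbon, seven bonds along the chain from a carbonyl carbon, gives a 1.3-fold lower number from compound 1 to compound 3 (0.10 log units; within the scatter), which lies within the scatter, so this assay does not separate the saturated chain of compound 3 from the chain of compound 1 with its double bond. No measurement shown here accounts for either step.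

Across these compounds, chain length and the double bond change together, so neither can be weighed alone. From the compounds shown here alone, how a saturated chain as long as that of compound 2, a still shorter chain, or an amine or a carboxylic acid at the chain end would read at this position remains open.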